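A few compounds are considered here, and "the series" means these few. Any claim that something is new, unique, unknown or untested is made for them only; others in the source may bear on it.

Measured so far in an ADME assay on microsomes from liver (Mus musculus) for metabolic stability, read by LC-MS, using NADPH, tested at 1 uM; on this read-out lower numbers stand for a shorter-lived compound and higher numbers for a longer-lived compound:
- compound 1 `Cc1nc2c(N)ncnc2n1[C@@H]1O[C@H](CN(C)C/C=C\CNC(=O)OC(C)C)[C@@H](O)[C@H]1O`: > 1.5 h
- compound 2 `CN(C/C=C\CN)C[C@H]1O[C@@H](n2cnc3c(N)ncnc32)[C@@H]2OC(C)(C)O[C@@H]21`: > 1.5 h

Compound 2 has no numerical half-life, only a limit of the assay (> 1.5 h). Compound 1 likewise gives only a limit (> 1.5 h). Within the data shown here, the evidence so far is therefore thin (the limit of > 1.5 h in this assay, at which 2 of the 2 values shown sit): no order can be set between these two compounds, and no measured step between compounds differing in one place is available as a guide.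

Compound 3 `CNc1ncnc2c1ncn2[C@@H]1O[C@H](CN(C)C/C=C\CN)[C@H]2OC(C)(C)O[C@H]21` differs from compound 2 by a single change (methyl in place of hydrogen on a nitrogen on an aromatic ring), with methyl in place of hydrogen on a nitrogen on an aromatic ring, or amino to methylamino.

Among the measured compounds shown here, with no measured step to draw on, the step expected in this assay is none beyond the usual scatter, and no direction is favoured (a number no higher from compound 2 to compound 3 (the limit leaves the size open)). For compound 3 the estimated half-life is 1.5 h (expected range 0.7 h to 3 h). A report of only a limit is also expected to be about as likely as a number.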

Compound 3, half-life: > 1.5 h
Compound 3 ended at the assay's limit; the forecaster's own chance of this, stated with the estimate: 55%; the middle value sits exactly at the limit.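

Compound 2 and compound 3 both end at a limit of this assay rather than at a number, so the step of methyl in place of hydrogen on a nitrogen on an aromatic ring cannot be read. The compounds shown leave open whether this change alters the half-life at all, and how the three compounds order: the limit of > 1.5 h in this assay, at which 3 of the 3 values shown sit.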